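The compounds below may be only part of what the source reports. "The series", "measured", "known", "first", "only" and "open" are said of these compounds alone.

Compound 1, `Fc1cccc(F)c1Cc1cnc(Nc2ccc(Oc3cccnc3)c(Cl)c2)o1`, is the starting point of this step. In an ADME assay on MT2 cells (Homo sapiens) for cytotoxicity, read by MTT assay (a lower number here means that less compound is tolerated, a higher number that more compound is tolerated), compound 1 gives 16000 nM. Among the measured compounds shown here, only one other compound here gives a plain number: compound 3, `Fc1cccc(F)c1Cc1cnc(Nc2ccc(Oc3cccnc3)cc2)o1`, gives 22000 nM in this assay, and the step of a 1.4-fold higher number from compound 1 to compound 3 (0.14 log units; within the scatter), which replaces a chloro on an aromatic carbon with hydrogen, lies within the scatter, so compound 1 and compound 3 cannot be told apart on these numbers. Compound 2, `Clc1cccc(Cl)c1Cc1nnc(Nc2ccc(COCc3ccsc3)cc2)o1`, gives only a limit in this assay, > 100000 nM, which is the limit of > 100000 nM in this assay, at which 1 of the 3 values shown sits.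

Compound 4, `Fc1cccc(F)c1Cc1cnc(Nc2ccc(COc3ccncc3)c(Cl)c2)o1`, has not yet been measured. It differs from compound 1 in one place: ((pyridin-4-yl)oxy)methyl in place of (pyridin-3-yl)oxy on an aromatic carbon. For the measured compounds named here, none of the measured steps touches this part of the molecule; the only measured step concerns the chloro group, and compound 2 differs from the others in too many places to count as a single step. There is therefore no measured evidence pointing to a change in this assay in either direction, and the expectation is a step no larger than the scatter. Compound 4 is thus expected to give about 18000 nM in this assay, between 7000 nM and 45000 nM, meaning an expected step of a 1.1-fold higher number from compound 1 to compound 4 (0.05 log units; within the scatter).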

Compound 4, half-maximal cytotoxic concentration: 3800 nM
Estimate against measurement, compound 4: 4.7-fold (0.68 log units) above; measured number outside the range, below it.
By their numbers in this assay, from the lowest: compound 4; then compounds 1 and 3 (each within the scatter of the next). At a limit, above all of these: compound 2.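

Among the compounds shown here, until now the only measured step on this ring was the loss of the chloro group, which stayed within the scatter, so nothing showed whether the ring was sensitive to change at all. The large group at the position para to the shared core's link tells a different story, since in this assay replacing (pyridin-3-yl)oxy with ((pyridin-4-yl)oxy)methyl gives a 4.2-fold lower number from compound 1 to compound 4 (0.62 log units; beyond the scatter) and so this position does move the number, towards less compound being tolerated. For the compounds shown here, the one piece of supporting information on hand concerns only the limit of compound 2 and does not bear on this step.

The change alters two things at once, a methyl link and pyridin-4-yl in place of pyridin-3-yl, and the compounds shown do not separate the two, nor do they show whether the step would hold without the chloro group. Also open, on these data alone, is how this assay would respond to an amine or a carboxylic acid at this position, or to a longer chain in place of the methyl link.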